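This account rests on a few compounds, and the source may have more. Where it says the series, first, only, none or still open, it means among the compounds named here.

In a functional assay on MCF7 cells (Homo sapiens) for inhibition, read by MTT assay, with a stated time of 24 h (on this read-out higher numbers stand for weaker inhibition and lower numbers for stronger inhibition), compound 1 `CCOC(=O)C1=Cc2ccccc2OC1(OCc1cn(CC(=O)NC2CCCCC2)nn1)C(F)(F)F` gives 12100 nM and stands lowest of the two numbers at hand. Compound 2 `Cc1ccc(-c2cc(COC3(C(F)(F)F)Oc4ccccc4C=C3C(=O)O)on2)cc1` gives 30100 nM in this assay, a higher number beyond the scatter. Compound 3 `O=C(O)C1=Cc2ccccc2OC1(OCc1cc(-c2ccc([N+](=O)[O-])cc2)no1)C(F)(F)F` returns only a limit of this assay, > 150000 nM in this assay, namely the limit of > 150000 nM in this assay, at which 1 of the 3 values shown sits, for this assay. Among the measured compounds shown here, the single measured step, an at least 4.9-fold higher number from compound 2 to compound 3 (0.69 log units; beyond the scatter) in this assay, is the only one that bears here, and it concerns a nitro group on a different part of the shared core. Compound 4 `CCOC(=O)C1=Cc2ccccc2OC1(OCc1cn(-c2ccc([N+](=O)[O-])cc2)nn1)C(F)(F)F` differs from compound 1 by 4-nitrophenyl in place of (cyclohexylcarbamoyl)methyl on an aromatic nitrogen on the shared core. Since compound 2 and compound 3 showed an at least 4.9-fold higher number from compound 2 to compound 3 (0.69 log units; beyond the scatter) in this assay, a weakening step is expected, of size a 3.3-fold higher number from compound 1 to compound 4 (0.52 log units; beyond the scatter) in this assay. Compound 4 is therefore expected to give 40000 nM in this assay, within 12000 nM to 150000 nM in this assay.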

Compound 4, half-maximal inhibitory concentration: > 150000 nM
Compound 4 ended at the assay's limit (the forecaster's own chance of this, stated with the estimate: 25%); middle value at least 3.7-fold (0.57 log units) from the limit.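

On the aromatic nitrogen, 4-nitrophenyl in place of (cyclohexylcarbamoyl)methyl gives an at least 12-fold higher number from compound 1 to compound 4 (1.09 log units; beyond the scatter) in this assay, the first step shown at this position, and a large one. Compound 4 gives > 150000 nM, which is a limit of the assay. Both compounds shown that carry 4-nitrophenyl, compound 3 and compound 4, now sit at one value: the limit of > 150000 nM in this assay, at which 2 of the 4 values shown sit.

The compounds shown leave open whether the step follows the entering 4-nitrophenyl or the loss of (cyclohexylcarbamoyl)methyl. A plain phenyl or a 4-aminophenyl on this nitrogen would help to separate the two.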